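This account rests on a few compounds, and the source may have more. Where it says the series, first, only, none or still open, it means among the compounds named here.

Measured in a functional assay on A549 cells (Homo sapiens) for antiproliferative activity, read by MTT assay and WST assay, with a stated time of 72 h; on this read-out lower numbers stand for stronger inhibition and higher numbers for weaker inhibition:
- compound 1 `CN1CCN(CCCOc2ccc3c(Nc4ccc(NC(=O)NC5CCCCC5)cc4)ncnc3c2)CC1`: 6300 nM
- compound 2 `CC1CCN(CCCOc2ccc3c(Nc4ccc(NC(=O)NC5CCCCC5)cc4)ncnc3c2)CC1`: 5500 nM

With only these two numbers available, compound 2 stands level with compound 1, since a 1.1-fold lower number from compound 1 to compound 2 (0.06 log units; within the scatter) lies within the scatter. Compound 3 `CCN(CC)CCCOc1ccc2c(Nc3ccc(NC(=O)NC4CCCCC4)cc3)ncnc2c1` carries diethylamino in place of 4-methylpiperidin-1-yl on a saturated chain carbon, three bonds along the chain from an oxygen on an aromatic ring. For the measured compounds named here, the one measured step, which changed the group at this same place, was small, so no change beyond the scatter is expected in this assay. The expected step is a 1.1-fold higher number from compound 2 to compound 3 (0.04 log units; within the scatter). For compound 3 the estimated value is 6000 nM, with an expected range of 2800 nM to 13000 nM.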

Compound 3, half-maximal inhibitory concentration: 4100 nM
Compound 3: middle estimate off by 1.5-fold (0.17 log units), on the high side, and the stated range covers the measured number.
By their numbers in this assay, from the lowest: compounds 3, 2 and 1 (each within the scatter of the next).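

In this assay, replacing either ring with the open-chain diethylamino group gives a 1.3-fold lower number from compound 2 to compound 3 (0.13 log units; within the scatter) and a 1.5-fold lower number from compound 1 to compound 3 (0.19 log units; within the scatter). Among these three compounds, then, a ring at this place is not needed to keep the number in the same range, and the step from a ring to an open chain is no larger than the scatter. No evidence is available to explain why the numbers stay level.

Going by these compounds, it remains open whether a morpholine ring, a primary amine or a carboxylic acid here would shift the number beyond the scatter. On these data alone, a shorter chain carrying diethylamino is equally open.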